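Swapping the Thiadiazole for an Imidazole on the Amide

The source may hold more compounds than are shown below. What is called first, only, known or untested is meant among the compounds shown, and "the series" means these compounds.

In a functional assay on CHO cells for agonist activity at Free fatty acid receptor 2 (Homo sapiens), read by cAMP accumulation (a higher number here means a larger maximal response, a lower number a smaller maximal response), the three measured compounds gave these values:
compound 1 `CNC(=O)[C@H](c1ccc(Cl)cc1)C(C)C`: 66%
compound 2 `CC(C)[C@H](C(=O)Nc1ccc(F)cn1)c1ccc(Cl)cc1`: 93%
compound 3 `CC(C)[C@H](C(=O)Nc1ncns1)c1ccc(Cl)cc1`: 99%

Compound 3 has the highest number of the three, but its gap to compound 2 lies within the scatter, so these two cannot be ranked; only compound 1 stands clearly lower. Compound 4 `CC(C)[C@H](C(=O)Nc1ncc[nH]1)c1ccc(Cl)cc1` differs from compound 3 in one place: 1H-imidazol-2-yl in place of 1,2,4-thiadiazol-5-yl on an amide-type nitrogen. Among the measured compounds shown here, the steps that bear on this are a number 33 percentage points higher from compound 1 to compound 3 (beyond the scatter) and a number 27 percentage points higher from compound 1 to compound 2 (beyond the scatter), which show that two different aromatic rings on the amide-type nitrogen gave a larger maximal response than methyl, while a number 6 percentage points higher from compound 2 to compound 3 (within the scatter) shows that exchanging one such ring for another changed little. A third aromatic ring is therefore expected to give only a small step: a number 9 percentage points lower from compound 3 to compound 4 (within the scatter) is the estimated change. For compound 4 the expected value is 90%, within 70% to 105%.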

Compound 4, largest response reached (reported as efficacy), in percent of the reference or control that the assay uses: 55%
The estimate for compound 4 lay 35 percentage points above the measured number; measured number outside the range, below it.
By their numbers in this assay, from the lowest: compound 4; then compound 1; then compounds 2 and 3 (each within the scatter of the next).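

At this amide-type nitrogen, an aromatic ring alone does not secure a large maximal response: 1H-imidazol-2-yl gives a number 44 percentage points lower from compound 3 to compound 4 (beyond the scatter) and a number 38 percentage points lower from compound 2 to compound 4 (beyond the scatter) and also a number 11 percentage points lower from compound 1 to compound 4 (beyond the scatter) so here a ring falls short even of methyl. The two five-membered rings match in heavy-atom count, yet only 1H-imidazol-2-yl carries a hydrogen-bond donor. No evidence at hand explains this drop.

Going by these compounds, whether that donor matters stays open. 1-Methyl-1H-imidazol-2-yl on the same nitrogen would put the same ring to the test without the ring hydrogen.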